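Swapping the bromine-bearing ring of a hydrazone for a dichlorophenyl

This account rests on a few compounds, and the source may have more. Where it says the series, first, only, none or still open, it means among the compounds named here.

Compound 1, `Clc1cncc(Cl)c1N/N=C/c1ccccc1-c1ccccc1Br`, was tested in an assay on CHO cells for displacement of a labelled ligand from Substance-P receptor (Homo sapiens) (on this read-out lower numbers stand for stronger inhibition and higher numbers for weaker inhibition), and gives 49 nM. Among the two finished numbers in this assay it is the higher one. Compound 2, `Cc1ccccc1-c1ccc(N2CCN(C)CC2)nc1N(C)C(=O)C(C)(C)c1cc(C(F)(F)F)cc(C(F)(F)F)c1`, gives 2 nM in this assay, a lower number beyond the usual scatter. Compound 3, `CC(C)(NC(=O)c1ccccc1-c1ccccc1)c1cc(C(F)(F)F)cc(C(F)(F)F)c1`, reaches only the limit of the assay, > 10000 nM, so no number is known for it; this is the case noted as the limit of > 10000 nM in this assay, at which 1 of the 3 values shown sits.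

Compound 4, `Clc1cncc(Cl)c1N/N=C/c1ccccc1-c1c(Cl)cccc1Cl`, has not yet been measured. It differs from compound 1 in one place: 2,6-dichlorophenyl in place of 2-bromophenyl on an aromatic carbon. For the measured compounds named here, no pair of measured compounds shows this change, so its effect in this assay can only be guessed from compound 1 itself. The step from compound 1 to compound 4 is expected to be small, a 1.1-fold lower number from compound 1 to compound 4 (0.04 log units; within the scatter), with no clear direction beyond the scatter. Compound 4 is therefore estimated to give 45 nM in this assay, within a range from 12 nM to 180 nM.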

Compound 4, inhibition constant: 93 nM
The estimate for compound 4 lay 2.1-fold (0.32 log units) below the measured number; measured number inside the range.
By their numbers in this assay, from the lowest: compound 2; then compounds 1 and 4 (each within the scatter of the next). At a limit, above all of these: compound 3.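

In this assay, putting 2,6-dichlorophenyl in place of 2-bromophenyl gives a 1.9-fold higher number from compound 1 to compound 4 (0.28 log units; within the scatter), the only single-place change shown here. This position on the shared core therefore accepts either halogen-bearing ring, with no difference that can be told apart from the usual variation between repeated measurements. Nothing measured here accounts for this similarity.

Going by these compounds, both groups are phenyl rings carrying halogen, with no hydrogen-bond donors or acceptors, so it remains open how a phenyl ring bearing an amine or a carboxylic acid would behave at this position. Also open, on these data alone, is whether plain phenyl, with no halogen at all, would stay within the usual variation of these two compounds.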